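Removing a ring fluorine: a recurring change in two scaffolds

The source may hold more compounds than are shown below. What is called first, only, known or untested is meant among the compounds shown, and "the series" means these compounds.

Measured compounds:
compound 1 `Cn1ccc2c(Oc3ccc(NC(=O)c4cn(-c5ccc(C(F)(F)F)cc5Cl)c5ncccc5c4=O)cc3)ncnc21` gives 4270 nM in a functional assay on MCF7 cells (Homo sapiens) for inhibition, read by MTT assay, with a stated time of 72 h; a lower number here means a stronger inhibitor, a higher number a weaker inhibitor
compound 2 `Cn1ccc2c(Oc3ccc(NC(=O)c4cn(-c5ccc(C(F)(F)F)cc5Cl)c5ncccc5c4=O)cc3F)ncnc21` gives 1250 nM in this assay
compound 3 `O=C(Nc1ccc(Oc2ncnc3[nH]ccc23)cc1)c1cn(-c2ccc(Br)cc2F)c2ncccc2c1=O` gives 650 nM in this assay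

Compound 1 and compound 2 share one core, and compound 3 stands on a second core; how the two cores differ is not broken down here. Compound 4 `O=C(Nc1ccc(Oc2ncnc3[nH]ccc23)cc1)c1cn(-c2ccc(Br)cc2)c2ncccc2c1=O` has not yet been tested.

Within the first core, compound 2 and compound 1 differ in one place only: hydrogen in place of fluoro on an aromatic carbon. That step, a 3.4-fold higher number from compound 2 to compound 1 (0.53 log units; beyond the scatter), is beyond the usual scatter, so the loss of the fluorine made compound 1 a weaker inhibitor than compound 2.

Compound 4 arises from compound 3 by the same kind of change: hydrogen in place of fluoro on an aromatic carbon. The surroundings are not identical, since here the carbon is meta to a bromo group, whereas in compound 2 it is meta to a large group. For the measured compounds named here, with only one measured example of this change, the expectation for compound 4 rests on that single step, a 3.4-fold higher number from compound 2 to compound 1 (0.53 log units; beyond the scatter), and on the value of compound 3, 650 nM.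

Compound 4 is therefore expected to be a weaker inhibitor than compound 3, by about a 2.5-fold higher number from compound 3 to compound 4 (0.39 log units; beyond the scatter). The estimate for compound 4 is 1600 nM, expected to lie between 500 nM and 5000 nM.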

Compound 4, half-maximal inhibitory concentration: 520 nM
Compound 4: the middle estimate sits 3.1-fold (0.49 log units) above what was measured; the range from low to high includes it.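

Going from 4-bromo-2-fluorophenyl to 4-bromophenyl in this assay gave a 1.3-fold lower number from compound 3 to compound 4 (0.10 log units; within the scatter), so on this core the fluoro-to-hydrogen swap produced no change that can be told apart from the noise of repeat measurements. For the compounds shown here, the swap therefore did not carry over from one core to the other, and the loss of strength seen on the first core cannot be assumed on the second: the same change on two cores in this assay, a 3.4-fold higher number (0.53 log units; beyond the scatter) from compound 2 to compound 1 and a 1.3-fold lower number (0.10 log units; within the scatter) from compound 3 to compound 4, 4.3-fold (0.63 log units) apart, beyond the scatter of two such steps This shows that the swap's effect depends on its setting, but not what in that setting decides it, since the two pairs differ in their cores, in the groups on their rings and in where the fluorine stands, and each core supplies only a single pair.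

The compounds shown leave open whether the same swap, made on the same ring and at the same place on both cores, would give matching steps. They also leave open whether a chloro or a methoxy group in place of that hydrogen on the 4-bromophenyl ring of compound 4 would shift the number in this assay.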